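The compounds below may be only part of what the source reports. "The series", "measured", "known", "first", "only" and "open" are said of these compounds alone.

In a functional assay on the whole organism with Mus musculus as the target (a higher number here means that more compound is needed for the effect, a lower number that less compound is needed), compound 1 `COc1cc2c(cc1OC)C(c1ccc(N)cc1)=NN=C(S)C2` gives 6.3 umol/kg, the lower of the two numbers available. Compound 2 `COc1cc2c(cc1OC)C(c1ccc(Br)cc1)=NN(C)C(=S)C2` gives 105 umol/kg, a gap beyond the usual scatter. Compound 3 `COc1cc2c(cc1OC)C(c1ccccc1)=NN=C(S)C2` keeps the core of compound 1 but has hydrogen in place of amino on an aromatic carbon. Among the measured compounds shown here, no measured pair of compounds shows this change alone, so the expectation is loose: a moderate rise beyond the scatter, estimated as a 4.0-fold higher number from compound 1 to compound 3 (0.60 log units; beyond the scatter). For compound 3 the expected value is 25 umol/kg, with an estimated range of 8 umol/kg to 80 umol/kg.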

Compound 3, dose for half-maximal effect: 19.7 umol/kg
For compound 3 the middle estimate is 1.3-fold (0.10 log units) above the measured one; the range from low to high includes it.
By their numbers in this assay, from the lowest: compound 1; then compound 3; then compound 2.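

In this assay, among the compounds shown here, going from 4-aminophenyl to phenyl gives a 3.1-fold higher number from compound 1 to compound 3 (0.50 log units; beyond the scatter), the first direct reading of this one change. More compound is needed without the amino group, yet the step is modest and compound 3 still gives a dose for the effect, so this amino group is helpful here but not required. No available measurement explains the step. Still open, on these data alone, is how other groups at this place would compare, such as a hydroxyl, a dimethylamine or a carboxylic acid, and whether the step would hold on another core.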